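Amino for Chloro in a Growth Inhibition Series

The source may hold more compounds than are shown below. What is called first, only, known or untested is meant among the compounds shown, and "the series" means these compounds.

Compound 1, `Nc1nn(C(=O)Nc2ccc(Cc3ccccc3)cc2)c2ccccc12`: > 100000 nM
Compound 2, `Nc1nn(C(=O)Nc2ccc(Cc3ccccc3)cc2)c2ccc(Cl)cc12`: > 100000 nM

In a functional assay on SK-MEL-28 cells (Homo sapiens) for antiproliferative activity, read by sulforhodamine B assay, with a stated time of 48 h (a lower number here means a stronger inhibitor of growth, a higher number a weaker inhibitor of growth), compound 1 gives > 100000 nM, which is a limit of the assay and not a measured number. Compound 2 gives > 100000 nM, again a limit rather than a number. The step that the two limits leave unreadable from compound 1 to compound 2 therefore cannot be read; both values sit at the limit of > 100000 nM in this assay, at which 2 of the 2 values shown sit, so compound 2 stands at the limit with nothing more known about it.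

Compound 3, `Nc1ccc2c(c1)c(N)nn2C(=O)Nc1ccc(Cc2ccccc2)cc1`, differs from compound 2 by amino in place of chloro on an aromatic carbon. Within the data shown here, no measured step bears on this change, since the one measured step is unreadable, so there is no basis for expecting a step beyond the scatter in either direction in this assay. Compound 3 is therefore expected to give 100000 nM, in the range 30000 nM to 300000 nM. The estimated step of a number no higher from compound 2 to compound 3 (the limit leaves the size open) is expected to stay within the scatter, with a limit the most likely outcome.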

Compound 3, concentration for total growth inhibition: 27800 nM
Compound 3: middle estimate off by 3.6-fold (0.56 log units), on the high side; the measured number lies below the stated range.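

Putting amino in place of chloro on this aromatic carbon gives an at least 3.5-fold lower number from compound 2 to compound 3 (0.55 log units; beyond the scatter), and putting amino in place of hydrogen at the same carbon gives an at least 3.5-fold lower number from compound 1 to compound 3 (0.55 log units; beyond the scatter). The earlier pair could not show that this position affects the read-out, since the step between its two limits cannot be read. Among these compounds, compound 3 now shows that it does, as the only compound here to give a number rather than a limit in this assay: the limit of > 100000 nM in this assay, at which 2 of the 3 values shown sit.

On these data alone, both steps are minimum sizes, so how large the gain really is stays open. As far as these compounds go, it also remains open whether a methylamino group, a hydroxyl group or an acetamido group on this carbon would match amino, or whether amino would have the same effect elsewhere on the ring.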